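Arylsulfonyl Exchange on a Shared Tetrahydroquinoline Amide Core

The compounds below may be only part of what the source reports. "The series", "measured", "known", "first", "only" and "open" are said of these compounds alone.

Measured so far:
compound 1, `CN1CCC(N(C)C(=O)C2CN(S(=O)(=O)c3cccc4ccccc34)c3ccccc32)CC1`: 31.6 nM
compound 2, `CN1CCC(N(C)C(=O)C2CN(S(=O)(=O)c3cccc4nsnc34)c3ccccc32)CC1`: 126 nM

Both were tested in a functional assay on CHO cells for antagonist activity at 5-hydroxytryptamine receptor 6 (Homo sapiens), read by FLIPR; a lower number here means a stronger inhibitor, a higher number a weaker inhibitor. Among the compounds with values here, compound 2 holds the highest number of the two, the only other being compound 1, reached by a 4.0-fold higher number from compound 1 to compound 2 (0.60 log units; beyond the scatter). Compound 3, `CN1CCC(N(C)C(=O)C2CN(S(=O)(=O)c3ccc(OC(F)(F)F)cc3)c3ccccc32)CC1`, differs from compound 2 by a group of 11 heavy atoms (7 carbon, 1 oxygen, 3 fluorine; one six-membered aromatic ring of carbon only) in place of a group of 9 heavy atoms (6 carbon, 2 nitrogen, 1 sulfur; one five-membered aromatic ring with 3 hetero atoms, one six-membered aromatic ring of carbon only), on a sulfonyl sulfur. Within the data shown here, only the step from compound 1 to compound 2 touches the same sulfonyl sulfur, and it was modest, so a change of similar or smaller size is expected, most likely toward a lower number. Compound 3 is estimated at 60 nM, range 15 nM to 250 nM, that is a 2.1-fold lower number from compound 2 to compound 3 (0.32 log units; beyond the scatter).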

Compound 3, inhibition constant: 20 nM
Beside the measured number, compound 3's estimate is 3.0-fold (0.48 log units) above it, within the range that was stated.
By their numbers in this assay, from the lowest: compounds 3 and 1 (each within the scatter of the next); then compound 2.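

On the sulfonyl sulfur, in this assay, putting 4-(trifluoromethoxy)phenyl in place of the group of compound 2 gives a 6.3-fold lower number from compound 2 to compound 3 (0.80 log units; beyond the scatter) and so more than reverses the earlier loss. Set against naphthalen-1-yl, the same group gives a 1.6-fold lower number from compound 1 to compound 3 (0.20 log units; within the scatter) and so shows that a single six-membered aromatic ring can match the two-ring group at this position, leaving compound 2 alone apart from the other two. Nothing measured here accounts for this difference. The compounds shown leave open whether an unsubstituted phenyl, or a phenyl carrying an amine or a carboxylic acid, would hold this level on the sulfonyl sulfur.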